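Ethyl on the benzylic amine: from compound 3 to compound 4

The compounds below may be only part of what the source reports. "The series", "measured", "known", "first", "only" and "open" are said of these compounds alone.

Compound 1, `Cc1cc(N)c(Sc2ccccc2CN(C)C)cc1F`, in an assay on HEK293 cells for displacement of a labelled ligand from sodium-dependent dopamine transporter (Homo sapiens) (on this read-out higher numbers stand for weaker inhibition and lower numbers for stronger inhibition), gives > 10000 nM, a limit of the assay.
Compound 2, `CN(C)Cc1ccccc1Sc1ccc(CCF)cc1N`, gives > 10000 nM, also a limit.
Compound 3, `Cc1ccc(Sc2ccccc2CN)c(N)c1`, gives 5300 nM.

Among the compounds with values here, compound 3 thus holds the only number in this set; the other two values sit at the limit of > 10000 nM in this assay, at which 2 of the 3 values shown sit. Compound 4, `CCNCc1ccccc1Sc1ccc(C)cc1N`, differs from compound 3 by ethyl in place of hydrogen on an amine nitrogen. Within the data shown here, no step between two measured compounds is available to calibrate this change, so the expectation rests on compound 3 alone. A step of a 1.2-fold lower number from compound 3 to compound 4 (0.07 log units; within the scatter) is expected, which is within the usual scatter. Compound 4 is therefore estimated at 4500 nM in this assay, with a range from 1500 nM to 15000 nM.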

Compound 4, inhibition constant: 2120 nM
Compound 4: the middle estimate sits 2.1-fold (0.33 log units) above what was measured; measured number inside the range.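

Ethyl in place of hydrogen on the amine nitrogen brings a 2.5-fold lower number from compound 3 to compound 4 (0.40 log units; beyond the scatter) in this assay, the only step that can be read in this set. It shows that this nitrogen can carry an ethyl group without loss of inhibition, and that the modest change runs towards stronger inhibition. Compounds 1 and 2 give no comparison for this step, since their values are limits of the assay: the limit of > 10000 nM in this assay, at which 2 of the 4 values shown sit.

As far as these compounds go, whether a propyl chain or a cyclopropyl ring on this nitrogen would extend the change remains open. A single step on one core also cannot show whether the effect holds elsewhere.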